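Cyclopentyl Amide Joins Three Analogues Without Measurable Toxicity

A few compounds are considered here, and "the series" means these few. Any claim that something is new, unique, unknown or untested is made for them only; others in the source may bear on it.

Compound 1 `COc1ccc(-c2cnc(NC(=O)c3ccccc3F)n2C)cc1`: in a toxicity assay on THP-1 cells (Homo sapiens) for inhibition (on this read-out higher numbers stand for lower toxicity in this test and lower numbers for higher toxicity in this test), compound 1 gives > 100000 nM, which is a limit of the assay.
Compound 2 `COc1ccc(-c2cnc(NC(=O)C3CCCCC3)n2C)cc1`: in this assay compound 2 gives > 100000 nM, again a limit.
Compound 3 `COc1ccc(-c2cnc(NC(=O)c3cccnc3)n2C)cc1`: in this assay compound 3 gives > 100000 nM, also a limit.

Compound 3 therefore stands where every measured compound of the series stands, at the limit of > 100000 nM in this assay, at which 3 of the 3 values shown sit. Compound 4 `COc1ccc(-c2cnc(NC(=O)C3CCCC3)n2C)cc1` is the next member to be measured; it differs from compound 3 by cyclopentyl in place of pyridin-3-yl on a carbonyl carbon. Among the measured compounds shown here, three measured steps bear on this kind of change, since each of them exchanges the group on the carbonyl carbon: a step that the two limits leave unreadable from compound 1 to compound 2, a step that the two limits leave unreadable from compound 1 to compound 3 and a step that the two limits leave unreadable from compound 2 to compound 3. None of them can be sized, because both ends of each step sit at the limit. Replacing one ring on the carbonyl carbon by another has so far never brought a value inside the measurable range, so for compound 4 no step beyond the scatter is expected, and the expected step is a number no higher from compound 3 to compound 4 (the limit leaves the size open). The estimate for compound 4 is 100000 nM, with a range from 50000 nM to 300000 nM, most probably again reported only as a limit.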

Compound 4, half-maximal cytotoxic concentration: > 100000 nM
Compound 4 was reported as a limit (the forecaster's own chance of this, stated with the estimate: 85%); the middle value lies on the limit itself.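

The result for compound 4 in this assay is again a limit, so its steps from compound 1, compound 2 and compound 3 cannot be read: the limit of > 100000 nM in this assay, at which 4 of the 4 values shown sit.

The compounds shown leave open whether any group on the carbonyl carbon would bring a value inside the measurable range of this assay.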